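One Exchange on a Shared Core, Tested in Mice

The compounds below may be only part of what the source reports. "The series", "measured", "known", "first", "only" and "open" are said of these compounds alone.

Of the compounds shown here, three built on one shared core have been tested in a functional assay on the whole organism (strain Swiss albino) with Mus musculus as the target, with a stated time of 0.5 h; on this read-out lower numbers stand for an effect already at smaller amounts and higher numbers for an effect only at larger amounts of compound. Compound 1 `O=C(N/N=C/c1ccc(Cl)cc1Cl)Nc1cccc2ccccc12` gives 300 mg/kg in this assay. Compound 2 `C/C(=N\NC(=O)Nc1cccc2ccccc12)c1ccc(C)cc1` gives 300 mg/kg in this assay, and compound 3 `COc1cc(/C=N/NC(=O)Nc2cccc3ccccc23)ccc1O` gives 300 mg/kg in this assay. Compound 1 therefore stands level with compounds 2 and 3 at the digits reported; its nearest neighbour is compound 2 and its furthest is compound 3, and in neither case is there any change at the digits reported, so all three lie within the scatter of one another. The three differ only in the group carried on the carbon with a double bond to nitrogen, and those differences leave the read-out unmoved.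

Compound 4 `O=C(N/N=C/c1ccccc1O)Nc1cccc2ccccc12` has not yet been measured in this assay. It differs from compound 1 by 2-hydroxyphenyl in place of 2,4-dichlorophenyl on a carbon with a double bond to nitrogen. Since the read-out did not move between compound 1 at 300 mg/kg and compound 3 at 300 mg/kg, a further exchange of the same kind is not expected to move it either. The step of no change at the digits printed from compound 1 to compound 4 (within the scatter) is expected to be none beyond the scatter. Compound 4 is accordingly estimated to give 300 mg/kg, in a range from 150 mg/kg to 600 mg/kg.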

Compound 4, minimum effective dose: 300 mg/kg
Estimate against measurement, compound 4: no gap at the digits printed; the range from low to high includes it.
By their numbers in this assay, from the lowest: compounds 1, 2, 3 and 4 (each within the scatter of the next).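

In this assay, going by these compounds alone, the exchange of 2,4-dichlorophenyl for 2-hydroxyphenyl on a carbon with a double bond to nitrogen gives no change at the digits printed from compound 1 to compound 4 (within the scatter), and this is the first step that can be read at a single place. It shows that the read-out at this position stays the same when the group that leaves, with 2 chlorine atoms and 0 hydrogen-bond donors or acceptors, gives way to one with 1 oxygen, 1 hydrogen-bond donor and 1 hydrogen-bond acceptor. Nothing available here accounts for this outcome in terms of any measured property of the two groups.

All the groups shown at this position carry a six-membered aromatic ring of carbon only, so it remains open whether an amine, a carboxylic acid or a longer chain in place of that ring would leave the read-out where it stands. The four compounds also share the rest of the core, and they leave open whether any exchange there would separate one compound from another in this assay.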